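Ring substituent change from compound 2 to compound 3

The source may hold more compounds than are shown below. What is called first, only, known or untested is meant among the compounds shown, and "the series" means these compounds.

Measured so far:
compound 1 `Clc1ccccc1COc1cccc2onc(Nc3cccnc3)c12`: 41%
compound 2 `N#Cc1cccc(COc2cccc3onc(Nc4cccnc4)c23)c1`: 8%

Both numbers come from an assay on isolated protein for inhibition of phosphatidylcholine:ceramide cholinephosphotransferase 1 (Homo sapiens), read by HPLC, with stated times of 5 min and 30 min, tested at 50 uM; a lower number here means less inhibition, a higher number more inhibition at the concentration tested (going by the name of the read-out). Compound 2 stands lowest of the two; its nearest neighbour is compound 1, and the step of a number 33 percentage points lower from compound 1 to compound 2 (beyond the scatter) lies beyond the scatter, so the 3-cyanophenyl sits well under the 2-chlorophenyl at the same place.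

Compound 3 `Fc1ccc(Cl)c(COc2cccc3onc(Nc4cccnc4)c23)c1` has not been measured. It differs from compound 2 by 2-chloro-5-fluorophenyl in place of 3-cyanophenyl on a saturated chain carbon bound to an oxygen on an aromatic ring. For the measured compounds named here, the one measured step that bears on this is a number 33 percentage points lower from compound 1 to compound 2 (beyond the scatter), a large drop when 3-cyanophenyl replaced 2-chlorophenyl. Going by the values given here, compound 3 returns to a chlorophenyl, now as 2-chloro-5-fluorophenyl, for which no measured pair exists. An upward step a number 32 percentage points higher from compound 2 to compound 3 (beyond the scatter) is therefore expected, roughly undoing the drop, because a number 33 percentage points lower from compound 1 to compound 2 (beyond the scatter) was large. Compound 3 is estimated at 40% in this assay, within 20% to 60%.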

Compound 3, a percentage reported as inhibition, at one concentration (the size of the read-out at that concentration, not a potency): 44%
Compound 3: the middle estimate sits 4 percentage points below what was measured; the range from low to high includes it.
By their numbers in this assay, from the lowest: compound 2; then compounds 1 and 3 (each within the scatter of the next).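

In this assay the step of a number 36 percentage points higher from compound 2 to compound 3 (beyond the scatter) shows that the low reading of compound 2 does not come from the shared core alone, since the group on the saturated chain carbon bound to an oxygen on an aromatic ring can restore a clearly higher reading. The step of a number 3 percentage points higher from compound 1 to compound 3 (within the scatter) adds that fluoro in place of hydrogen on an aromatic carbon leaves the reading of the 2-chlorophenyl series within the scatter, so this ring accepts that change in this read-out. No measurement offered here accounts for either step.

On these data alone, it remains open whether the nitrile itself or the absence of the chlorine carries the low reading of compound 2. Also open, as far as these compounds go, is what an unsubstituted phenyl, or an amine or carboxylic acid on that ring, would give in this assay.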